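Adding a methyl on the amide nitrogen of compound 1

A few compounds are considered here, and "the series" means these few. Any claim that something is new, unique, unknown or untested is made for them only; others in the source may bear on it.

- Compound 1 `COc1c(C(=O)Nc2ccc(NS(C)(=O)=O)cc2)cc(N2CCC(=O)NC2=O)cc1C(C)(C)C`: > 85%
- Compound 2 `COc1c(CNc2ccc(NS(C)(=O)=O)cc2)cc(N2CCC(=O)NC2=O)cc1C(C)(C)C`: 67%
- Compound 3 `COc1c(/C=C(\C)c2ccc([N+](=O)[O-])cc2)cc(N2CCC(=O)NC2=O)cc1C(C)(C)C`: 18.5%

These results come from an ADME assay on microsomes from liver (Homo sapiens) for metabolic stability, with a stated time of 30 min; a higher number here means that more of the compound is left, a lower number that less of the compound is left. Compound 1 gives > 85%, which is a limit of the assay and not a number. Compound 1 alone stands at the limit of > 85% in this assay, at which 1 of the 3 values shown sits. Compound 2 reads 67% and compound 3 reads 18.5%, so both sit lower on the scale.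

Compound 4 `COc1c(C(=O)N(C)c2ccc(NS(C)(=O)=O)cc2)cc(N2CCC(=O)NC2=O)cc1C(C)(C)C` keeps the rest of compound 1 and changes one place: methyl in place of hydrogen on an amide-type nitrogen. In words, this is methyl in place of hydrogen on an amide-type nitrogen. Going by the values given here, no measured pair shows this change, so any forecast is uncertain. For compound 1 the limit of > 85% leaves little room upward, so a modest downward step is expected in this assay, though it may stay within the scatter. The expected size is a number at least 13 percentage points lower from compound 1 to compound 4 (beyond the scatter). For compound 4 the estimated value is 72%, with an expected range from 50% to 90%.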

Compound 4, percent of the compound remaining in the liver assay: 64%
Beside the measured number, compound 4's estimate is 8 percentage points above it; low and high end bracket the measured number.
By their numbers in the liver assay, from the lowest: compound 3; then compounds 4 and 2 (each within the scatter of the next). At a limit, above all of these: compound 1.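

Methyl in place of hydrogen on this amide-type nitrogen gives, in the liver assay, a number at least 21 percentage points lower from compound 1 to compound 4 (beyond the scatter), so a single added carbon at this place is enough to move that read-out. In a physicochemical assay for solubility, at pH 7.2 (on this read-out lower numbers stand for lower solubility and higher numbers for higher solubility), the same change gives an at least 33-fold higher number from compound 1 to compound 4 (1.52 log units; beyond the scatter), so one small change moves the two read-outs in opposite directions, with less compound left but a higher solubility number. In the physicochemical assay compound 1 gives < 1500 nM as a limit of the assay. In the physicochemical assay compound 4 gives > 50000 nM as a limit of the assay too. Both values behind this second step are limits of the assay, so it gives a bound and not a size: the measured solubility of compound 1, < 1500 nM, and of compound 4, > 50000 nM, an at least 33-fold higher number (1.52 log units; beyond the scatter)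

The compounds shown leave open whether an ethyl group or a longer chain on this nitrogen would shift the liver assay and the physicochemical assay further, or differently. A single pair also cannot tell whether the two steps would always travel together.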